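The source may hold more compounds than are shown below. What is called first, only, known or untested is meant among the compounds shown, and "the series" means these compounds.

Measured in an ADME assay on CEM-SS cells (Homo sapiens) for cytotoxicity, read by XTT assay, with a stated time of 6 days; on this read-out higher numbers stand for lower toxicity in this test and lower numbers for higher toxicity in this test:
Compound 1 (`CCCC(=O)OCSc1ccc(OC(F)(F)F)cc1C(=O)NC(C)(C)C(N)=O`): < 56.1 uM
Compound 2 (`CCCC(=O)OCSc1ccccc1C(=O)NCC(N)=O`): > 100 uM

Neither entry is an exact number. For compound 2, the reading of > 100 uM in this assay is a limit of the assay. For compound 1, the reading of < 56.1 uM is likewise a limit.

Compound 3 (`CCCC(=O)OCSc1ccccc1C(=O)NCCCCCCC(N)=O`) has not yet been measured. It departs from compound 2 in a single place, with 5-carbamoylpentyl in place of carbamoyl on a saturated chain carbon bound to an amide-type nitrogen. Among the compounds with values here, no step between measured compounds is available to scale this change, so only a small move toward lower numbers is expected, possibly no more than the scatter. The estimated change is an at least 1.1-fold lower number from compound 2 to compound 3 (0.04 log units; that floor lies within the scatter) in this assay, and the result may again be only a limit. For compound 3, the expected value is 90 uM, with an estimated range from 35 uM to 200 uM.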

Compound 3, half-maximal toxic concentration: 10.4 uM
Compound 3: middle estimate off by 8.7-fold (0.94 log units), on the high side; measured number below the stated range.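

In this assay, within the data shown here, compound 3 gives 10.4 uM, the first exact number, which shows that the read-out responds to a change on a saturated chain carbon bound to an amide-type nitrogen. Putting 5-carbamoylpentyl in place of carbamoyl gives an at least 9.6-fold lower number from compound 2 to compound 3 (0.98 log units; beyond the scatter), although the hydrogen-bond donor and acceptor counts of the two groups are the same. The true size of this step remains unknown, since compound 2 is recorded only as a limit: the limit of > 100 uM in this assay, at which 1 of the 3 values shown sits.

The two compounds cannot show whether the lower number follows chain length in a graded way or appears only once the chain reaches a certain size. Going by these compounds, it also remains open whether a longer chain, or a chain ending in an amine or a carboxylic acid instead of the carbamoyl, would behave in the same way.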